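This account rests on a few compounds, and the source may have more. Where it says the series, first, only, none or still open, it means among the compounds named here.

Two urea compounds sharing the same core have been tested in a functional assay on HCT-116 cells (Homo sapiens) for inhibition, with a stated time of 72 h, in the presence of a further agent that is not named here; on this read-out higher numbers stand for weaker inhibition and lower numbers for stronger inhibition. For the measured compounds named here, there, compound 1, `CNc1nccc(N2CC[C@H](NC(=O)Nc3ccc(Cl)c(C(F)(F)F)c3)C2)n1`, gives 4400 nM, the only actual number available so far, and that number reflects weak inhibition. Compound 2, `CNc1nccc(N2CC[C@H](NC(=O)Nc3ccc(C)c(Cl)c3)C2)n1`, gives > 10000 nM in this assay, which is a limit of the assay and not a number.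

The next compound is compound 3, `CCN1CCN(Cc2ccc(NC(=O)N[C@H]3CCN(c4ccnc(NC)n4)C3)cc2C(F)(F)F)CC1`, which has not yet been measured. It differs from compound 1 in one place: (4-ethylpiperazin-1-yl)methyl in place of chloro on an aromatic carbon. In words, (4-ethylpiperazin-1-yl)methyl stands in place of chloro on an aromatic carbon, ortho to a trifluoromethyl group and para to a large group.

Going by the values given here, no measured pair of compounds shows what a single change does here, so any forecast is uncertain. With compound 1 at 4400 nM as the reference, a moderate move towards stronger inhibition is expected, though no change beyond the scatter remains possible. The estimate amounts to a 2.2-fold lower number from compound 1 to compound 3 (0.34 log units; beyond the scatter), an expected step of modest size. Compound 3 is expected at 2000 nM, with an estimated range of 400 nM to 10000 nM.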

Compound 3, half-maximal inhibitory concentration: 4800 nM
Beside the measured number, compound 3's estimate is 2.4-fold (0.38 log units) below it; measured number inside the range.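

In this assay, for the compounds shown here, the first single change that can be read is a 1.1-fold higher number from compound 1 to compound 3 (0.04 log units; within the scatter), with (4-ethylpiperazin-1-yl)methyl in place of chloro on an aromatic carbon. At this position, ortho to a trifluoromethyl group and para to a large group, a group of 9 heavy atoms with a six-membered non-aromatic ring thus stands where a single chlorine atom stood, and the two compounds cannot be told apart, both remaining at weak inhibition. Compound 2 gives a limit of the assay and not a number, and no step involving it can be read: the limit of > 10000 nM in this assay, at which 1 of the 3 values shown sits.

This single pair does not show whether the same holds for other groups at this position, such as a short dimethylaminomethyl group, a morpholine linked through a methylene, a carboxylic acid or a plain hydrogen. It also leaves open whether any change at this position can bring stronger inhibition in this assay, or whether the trifluoromethyl group on the same ring has a part in what is seen here.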